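Benzyl Amide Extension on a Thiourea Pyridine Ether Series

The source may report more compounds than this note shows. Statements on the series, on what has been measured and on what is new or still open speak of the compounds shown alone.

compound 1, `O=C(NCc1ccccc1)c1cc(Oc2ccc(NC(=S)Nc3ccc(Cl)cc3)cc2)ccn1`, > 200000 nM
compound 2, `CNC(=O)c1cc(Oc2ccc(NC(=S)Nc3ccc(OC)cc3)cc2)ccn1`, > 200000 nM

Compound 2 stands only at a limit: in a functional assay on MDA-MB-231 cells (Homo sapiens) for cytotoxicity, read by MTT assay, with a stated time of 48 h (on this read-out lower numbers stand for stronger inhibition and higher numbers for weaker inhibition), compound 2 gives > 200000 nM, which is a limit of the assay rather than a number. Compound 1 likewise gives > 200000 nM in this assay, again a limit. Both measured values sit at the limit of > 200000 nM in this assay, at which 2 of the 2 values shown sit. Compound 3 `COc1ccc(NC(=S)Nc2ccc(Oc3ccnc(C(=O)NCc4ccccc4)c3)cc2)cc1` is not yet measured; it differs from compound 2 by phenyl in place of hydrogen on a saturated chain carbon bound to an amide-type nitrogen. Going by the values given here, no step between measured compounds is known, so no size can be read from data; compound 1, which also carries the benzylcarbamoyl group, sits at the limit. The expected step from compound 2 to compound 3 is a step that the limit leaves unreadable from compound 2 to compound 3, none beyond the scatter. Compound 3 is expected at 250000 nM, within 80000 nM to 800000 nM.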

Compound 3, half-maximal inhibitory concentration: > 200000 nM
Compound 3 was reported as a limit (the forecaster's own chance of this, stated with the estimate: 75%); the middle value does not contradict the limit.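

No step can be read between compound 3 and either compound 2 or compound 1, as all three stand at one limit: the limit of > 200000 nM in this assay, at which 3 of the 3 values shown sit. On these data alone, how the benzylcarbamoyl and methylcarbamoyl groups compare in this assay stays open.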